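A few compounds are considered here, and "the series" means these few. Any claim that something is new, unique, unknown or untested is made for them only; others in the source may bear on it.

Measured in an assay on isolated protein for inhibition of Calpain-1 catalytic subunit (Sus scrofa), read by FRET; on this read-out higher numbers stand for weaker inhibition and lower numbers for stronger inhibition:
compound 1 `O=C(O)/C(S)=C/c1ccc(I)cc1` gives 2200 nM
compound 2 `O=C(O)/C(S)=C/c1ccc(Br)cc1` gives 1500 nM
compound 3 `O=C(O)/C(S)=C/c1cccc(Br)c1` gives 4000 nM

Compound 4 `O=C(O)/C(S)=C/c1cccc(I)c1` has not yet been measured. Compound 1 differs from compound 2 by iodo in place of bromo on an aromatic carbon, and in this assay this gave a 1.5-fold higher number from compound 2 to compound 1 (0.17 log units; within the scatter). Compound 3 has the same atoms as compound 2 joined differently; the difference between the two cores is not broken down here. In this assay compound 3 gives a higher number than compound 2, while compound 3 and compound 1 lie within the scatter of each other. Compound 4 differs from compound 3 by iodo in place of bromo on an aromatic carbon. This is the same kind of change as that from compound 2 to compound 1, but not the same: there the iodo sits para to a group of 6 heavy atoms, here meta to a group of 6 heavy atoms. A step of similar size is expected, a 1.4-fold higher number from compound 3 to compound 4 (0.14 log units; within the scatter), because the earlier change gave a 1.5-fold higher number from compound 2 to compound 1 (0.17 log units; within the scatter). Compound 4 is therefore estimated at 5500 nM, likely between 2500 nM and 12000 nM.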

Compound 4, half-maximal inhibitory concentration: 4300 nM
Compound 4: middle estimate off by 1.3-fold (0.11 log units), on the high side; low and high end bracket the measured number.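

In this assay, putting iodo in place of bromo gave a 1.1-fold higher number from compound 3 to compound 4 (0.03 log units; within the scatter). Set beside the same change on the other core, this step does not differ from the earlier one by more than repeated measurements would: the same change on two cores in this assay, a 1.5-fold higher number (0.17 log units; within the scatter) from compound 2 to compound 1 and a 1.1-fold higher number (0.03 log units; within the scatter) from compound 3 to compound 4, 1.4-fold (0.13 log units) apart, within the scatter of two such steps. Both steps stay within the scatter, so the change behaves alike on these two cores, but two pairs cannot show that it would do so on any other core, nor why the two halogens give such close results.

The compounds shown leave open what happens when the halogen is replaced by a group of another kind, such as an amine or a methoxy group. They also leave open how a longer chain in that place would fare.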